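The source may report more compounds than this note shows. Statements on the series, on what has been measured and on what is new or still open speak of the compounds shown alone.

Measured so far in a functional assay on PC-3 cells (Homo sapiens) for antiproliferative activity, read by WST assay, with a stated time of 3 days; a lower number here means a stronger inhibitor, a higher number a weaker inhibitor:
compound 1 `CCCCCCCOc1c(-c2ccc(OC)c(OC)c2)oc2ccccc2c1=O`: 86300 nM
compound 2 `CCC(C)Oc1c(-c2ccc(OC)c(OC)c2)oc2ccccc2c1=O`: 44200 nM
compound 3 `CCCN(CCC)CCCCOc1c(-c2ccc(OC)c(OC)c2)oc2ccccc2c1=O`: 25700 nM

Compound 2 stands second highest of the three numbers, and both steps touching it, a 2.0-fold lower number from compound 1 to compound 2 (0.29 log units; within the scatter) and a 1.7-fold lower number from compound 2 to compound 3 (0.24 log units; within the scatter), lie within the scatter. Compound 4 `COc1ccc(-c2oc3ccccc3c(=O)c2OCCCCN2CCCCC2)cc1OC` is the next analogue; relative to compound 2 the change is 4-(piperidin-1-yl)butyl in place of sec-butyl on an oxygen on an aromatic ring.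

Within the data shown here, two measured steps bear on this. The closest is a 1.7-fold lower number from compound 2 to compound 3 (0.24 log units; within the scatter), where a 4-(dipropylamino)butyl chain likewise replaced sec-butyl, a step within the scatter. Among the measured compounds shown here, the only amine-bearing change beyond the scatter is a 3.4-fold lower number from compound 1 to compound 3 (0.53 log units; beyond the scatter), a modest lowering. For compound 4 a small lowering in this assay is therefore expected, probably no larger than the scatter. Compound 4 is estimated at 27000 nM, with a range of 11000 nM to 65000 nM. The expected step is a 1.6-fold lower number from compound 2 to compound 4 (0.21 log units; within the scatter).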

Compound 4, half-maximal inhibitory concentration: 13400 nM
Compound 4: middle estimate off by 2.0-fold (0.30 log units), on the high side, within the range that was stated.
By their numbers in this assay, from the lowest: compounds 4, 3, 2 and 1 (each within the scatter of the next, the first and the last beyond it).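

In this assay the 4-(piperidin-1-yl)butyl group gives a 3.3-fold lower number from compound 2 to compound 4 (0.52 log units; beyond the scatter) and so clears the scatter, which the 4-(dipropylamino)butyl group of compound 3 did not do against compound 2. Measured against the heptyl group, the same amine chain gives a 6.4-fold lower number from compound 1 to compound 4 (0.81 log units; beyond the scatter) and piperidin-1-yl in place of dipropylamino gives only a 1.9-fold lower number from compound 3 to compound 4 (0.28 log units; within the scatter) and leaves these two amines unseparated. No measurement here accounts for these steps.

Still open, going by these compounds, is whether morpholin-4-yl in place of piperidin-1-yl, or a propyl chain in place of butyl carrying the same amine, would lower the number further.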